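Series notes: compound 1 to compound 3

This account rests on a few compounds, and the source may have more. Where it says the series, first, only, none or still open, it means among the compounds named here.

Of the compounds shown here, two have been measured in a functional assay on DU-145 cells (Homo sapiens) for cytotoxicity, read by MTT assay, with a stated time of 48 h; a lower number here means a stronger inhibitor, a higher number a weaker inhibitor. Compound 1 `CCOC(=O)c1c(-c2cc3ccccc3oc2=O)nn(-c2cccc(C)c2)c1C(=O)OCC` gives 47000 nM in this assay, the highest of the two numbers; compound 2 `CCOC(=O)c1c(-c2cc3ccccc3oc2=O)nn(-c2ccc(Cl)cc2)c1C(=O)OCC` gives 26000 nM. Going by the values given here, the single measured step, a 1.8-fold lower number from compound 1 to compound 2 (0.26 log units; within the scatter), exchanges 4-chlorophenyl for 3-methylphenyl on an aromatic nitrogen and stays within the scatter, so the data so far show no movement beyond repeat variation.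

Compound 3 `CCOC(=O)c1c(-c2cc3ccc(OCC=C(C)C)cc3oc2=O)nn(-c2cccc(C)c2)c1C(=O)OCC` keeps the 3-methylphenyl and the shared core of compound 1 and differs from it in one place: (3-methylbut-2-en-1-yl)oxy in place of hydrogen on an aromatic carbon The group enters on an aromatic carbon of a six-membered aromatic ring of carbon only, part of a fused system of two rings. Among the compounds with values here, no measured step touches this place; the one step available, a 1.8-fold lower number from compound 1 to compound 2 (0.26 log units; within the scatter), concerns the substituent on the aromatic nitrogen and gives no guidance on size or direction here. With nothing bearing on the change, compound 3 is expected near compound 1, the step of a 1.2-fold lower number from compound 1 to compound 3 (0.07 log units; within the scatter) expected to stay within the scatter, with a wide range. Compound 3 is estimated at 40000 nM, between 15000 nM and 110000 nM.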

Compound 3, half-maximal inhibitory concentration: 125000 nM
Estimate against measurement, compound 3: 3.1-fold (0.49 log units) below, and the stated range ends below it.
By their numbers in this assay, from the lowest: compounds 2 and 1 (each within the scatter of the next); then compound 3.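

Going by these compounds alone, the position on the six-membered aromatic ring of carbon only, part of the fused system of two rings, is the first place where a single change moves the number beyond the scatter: in this assay the step is a 2.7-fold higher number from compound 1 to compound 3 (0.42 log units; beyond the scatter) with (3-methylbut-2-en-1-yl)oxy in place of hydrogen on this aromatic carbon. Within the data shown here, the step is modest and runs toward a weaker inhibitor, so this position responds to substitution, while the one change on the aromatic nitrogen stays within the scatter. No supporting evidence bears on why the number rises at this position.

Going by these compounds, whether a methoxy group, a hydroxyl or an amine on this same aromatic carbon would move the number in the same direction remains open, as does whether the chain length or the double bond of the entering group matters to the step. Also open is whether the rise holds with the 4-chlorophenyl of compound 2 on the aromatic nitrogen, as the compounds shown carry this group only alongside the 3-methylphenyl.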